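A few compounds are considered here, and "the series" means these few. Any claim that something is new, unique, unknown or untested is made for them only; others in the source may bear on it.

Measured so far:
Compound 1, `CC[C@H](C)[C@H](N)CN(C(=O)[C@@H]1C[C@H]1c1ccc(Cl)cc1)c1ccc(-c2ccccc2)cc1`: in a functional assay for agonist activity at G protein-coupled receptor 88 (Homo sapiens), read by HTRF and cAMP accumulation (a lower number here means that less compound is needed, a higher number that more compound is needed for the effect), compound 1 gives 4300 nM.
Compound 2, `CC(C)C[C@H](N)CN(C(=O)[C@@H]1C[C@H]1c1ccccc1)c1ccc(-c2ccoc2)cc1`: in this assay compound 2 gives 2000 nM.

Of the two numbers seen so far, compound 2 has the lowest; the nearest is compound 1, whose number is higher by a gap that lies beyond the usual scatter. The next compound, compound 3, has the structure `CC(C)C[C@H](N)CN(C(=O)[C@@H]1C[C@H]1c1ccccc1)c1ccc(-c2ccc(Cl)cc2)cc1`. It differs from compound 2 in one place: 4-chlorophenyl in place of furan-3-yl on an aromatic carbon. For the measured compounds named here, no step between two measured compounds isolates this exchange, so no measured precedent says how large its effect is. The expected step in this assay from compound 2 to compound 3 is a small one toward a lower number, a 1.3-fold lower number from compound 2 to compound 3 (0.12 log units; within the scatter), an expectation that rests only on the two numbers in hand and may well fall within the scatter. Compound 3 is therefore estimated at 1500 nM, with a range from 500 nM to 5000 nM.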

Compound 3, half-maximal effective concentration: 640 nM
Compound 3: the middle estimate sits 2.3-fold (0.37 log units) above what was measured, within the range that was stated.
By their numbers in this assay, from the lowest: compound 3; then compound 2; then compound 1.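

For the compounds shown here, replacing furan-3-yl with 4-chlorophenyl gives a 3.1-fold lower number from compound 2 to compound 3 (0.49 log units; beyond the scatter) in this assay and offers the first single-place comparison in this small set. It shows that the number responds to the group on this aromatic carbon, para to a large group, by more than the usual scatter. The entering group has a six-membered aromatic ring of carbon only, a chlorine and no hydrogen-bond acceptor, so several features change in this one exchange. No measurement in hand explains the step.

As far as these compounds go, how much of the step belongs to the chlorine and how much to the six-membered ring stays open, and a 4-fluorophenyl or 4-methoxyphenyl group in the same place could help separate them. From the compounds shown here alone, whether an amine or a carboxylic acid on that outer ring would move the number in the same direction is also open.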